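A few compounds are considered here, and "the series" means these few. Any claim that something is new, unique, unknown or untested is made for them only; others in the source may bear on it.

Working notes on the series. Compound 1 `Cc1nc(-c2ccc(Cl)cc2)sc1C(=O)CSc1nc(-c2cccc(Cl)c2)c(C#N)c(=O)[nH]1` and compound 2 `COc1ccc(-c2nc(SCC(=O)c3sc(-c4ccc(Cl)cc4)nc3C)[nH]c(=O)c2C#N)cc1OC` share one core and differ only in the aryl group on the pyrimidinone part: 3-chlorophenyl in compound 1, 3,4-dimethoxyphenyl in compound 2. In a functional assay on U-87MG ATCC cells for antiproliferative activity against U-87 MG (Homo sapiens), read by MTT assay, with a stated time of 48 h, tested at 50 uM (a higher number here means a weaker effect of the compound at the concentration tested, a lower number a stronger effect), compound 1 gives 52.6%, and in the same run compound 2 gives 59.8%. The single measured step, a number 7.2 percentage points higher from compound 1 to compound 2 (within the scatter), is within the scatter, so on the numbers shown compound 2 sits alongside compound 1 rather than apart from it; nothing here separates the two.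

Compound 3 `COc1cccc(-c2nc(SCC(=O)c3sc(-c4ccc(Cl)cc4)nc3C)[nH]c(=O)c2C#N)c1` is the next member and is not yet measured in this assay. Relative to compound 2 its change is hydrogen in place of methoxy on an aromatic carbon. Among the measured compounds shown here, the only step that bears on it is the one from compound 1 to compound 2, which exchanged the whole aryl group and still stayed within the scatter; compound 3 keeps one methoxy and drops the other, a smaller alteration of the same ring. The step of a number 3.8 percentage points lower from compound 2 to compound 3 (within the scatter) is therefore expected to be small, with no direction beyond the scatter. For compound 3 the estimate is 56%, in the range 40% to 72%.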

Compound 3, a percentage reported as activity, at one concentration (the size of the read-out at that concentration, not a potency): 47.6%
Estimate against measurement, compound 3: 8.4 percentage points above; measured number inside the range.
By their numbers in this assay, from the lowest: compounds 3, 1 and 2 (each within the scatter of the next, the first and the last beyond it).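

Going from 3,4-dimethoxyphenyl to 3-methoxyphenyl gives the first step in the series that clears the scatter in this assay: a number 12.2 percentage points lower from compound 2 to compound 3 (beyond the scatter). A lower number means a stronger effect here, so losing the methoxy group para to a large group, with hydrogen entering in its place, strengthens the read-out at the concentration tested, although this rests on one pair. The step of a number 5 percentage points lower from compound 1 to compound 3 (within the scatter), with methoxy in place of chloro, does not separate those two compounds, and no measurement available here bears on why removing the methoxy group gives the larger step.

The compounds shown leave open whether hydrogen is particular at this carbon, or whether fluorine, a hydroxyl group, an amine or a longer chain such as ethoxy there would read like compound 3 or like compound 2. They also leave open whether the same removal would give a step of similar size with a different group in place of the remaining methoxy, and, since the read-out comes from a single concentration, how any of these compounds compare in potency.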